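From Bromo to Hydroxy on an Aromatic Carbon

A few compounds are considered here, and "the series" means these few. Any claim that something is new, unique, unknown or untested is made for them only; others in the source may bear on it.

Of the compounds shown here, three have been measured so far in a functional assay on MCF7 cells (Homo sapiens) for inhibition, read by MTT assay, with a stated time of 72 h (on this read-out higher numbers stand for weaker inhibition and lower numbers for stronger inhibition), and they do not sit evenly. Compound 1 (`COc1cc(NC(C)CCCNC(=O)NNC(=O)Nc2ccc(Br)cc2)c2ncccc2c1`) gives 100 nM as the lowest number of the three, and its distance to each of the other two lies beyond the scatter. Compound 2 (`COc1cc(NC(C)CCCNC(=O)Nc2cc(C(F)(F)F)cc(C(F)(F)F)c2)c2ncccc2c1`) reads 1600 nM and compound 3 (`COc1cc(NC(C)CCCNC(=O)NNC(=O)Nc2cc(C(F)(F)F)cc(C(F)(F)F)c2)c2ncccc2c1`) reads 2400 nM on this scale, two values within the scatter of each other.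

Compound 4 (`COc1cc(NC(C)CCCNC(=O)NNC(=O)Nc2ccc(O)cc2)c2ncccc2c1`) has not yet been measured. It keeps the core of compound 1 but carries hydroxy in place of bromo on an aromatic carbon, para to a large group, and hydroxy in place of bromo on an aromatic carbon is the whole of the difference. For the measured compounds named here, no two measured compounds differ in one place only, so the data give no direct measure of this change. Compound 1 holds 100 nM while the other two numbers lie far higher, so a single change from it seems more likely to raise the number than to lower it. A step of a 5.0-fold higher number from compound 1 to compound 4 (0.70 log units; beyond the scatter) is expected, toward weaker inhibition and beyond the scatter. For compound 4 the estimated value is 500 nM with an expected range of 100 nM to 2500 nM on this scale.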

Compound 4, half-maximal inhibitory concentration: 2600 nM
The estimate for compound 4 lay 5.2-fold (0.72 log units) below the measured number, and the stated range ends below it.
By their numbers in this assay, from the lowest: compound 1; then compounds 2, 3 and 4 (each within the scatter of the next).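

In this assay the change from bromo to hydroxy on an aromatic carbon, para to a large group, gives a direct reading of this position, with a 26-fold higher number from compound 1 to compound 4 (1.41 log units; beyond the scatter) and so a large move toward weaker inhibition. For the compounds shown here, the earlier compounds showed only that compound 1 stood apart from two others that differ from it in more than one place, whereas this pair ties a large loss to the exchange of one heavy atom with the rest of the molecule kept, so the position is far from indifferent to what it carries. Nothing available explains why the step is so large.

The compounds shown leave open whether the loss follows from the arrival of hydroxy or from the departure of bromo, as only these two groups appear at this place on an otherwise identical molecule. Chloro, methoxy, an amine or a carboxylic acid on the same aromatic carbon would show whether the low number of compound 1 is particular to bromo or is shared with other groups.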